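A few compounds are considered here, and "the series" means these few. Any claim that something is new, unique, unknown or untested is made for them only; others in the source may bear on it.

In a functional assay on KBVIN cells (Homo sapiens) for cytotoxicity, read by MTT assay, with a stated time of 72 h (on this read-out lower numbers stand for an effect already at smaller amounts and higher numbers for an effect only at larger amounts of compound), compound 1 `COc1cccc(Nc2cc(-c3ccccc3)oc(=O)c2)c1` gives 0.55 uM. Compound 2 `O=c1cc(NC2CC2)cc(-c2ccccc2)o1` returns only a limit of the assay, > 30 uM, and no number. Compound 3 `CCCCCc1cc(Nc2ccc(OC)cc2)cc(=O)o1` gives 4.84 uM, the higher of the two actual numbers, and its gap to compound 1 lies beyond the scatter of repeated measurements.

Compound 4 `COc1ccc(Nc2cc(C3CCCC3)oc(=O)c2)cc1` has not yet been measured. It departs from compound 3 in a single place: cyclopentyl in place of pentyl on an aromatic carbon. Cyclopentyl stands in place of pentyl on an aromatic carbon, next to the ring oxygen. Going by the values given here, no two measured compounds differ in only one place, so nothing measured so far tests this exchange directly. The expectation therefore starts from compound 3 at 4.84 uM and foresees no shift beyond the scatter in this assay. The expected change, a 1.1-fold higher number from compound 3 to compound 4 (0.06 log units; within the scatter), is small, although the uncertainty around it is wide. For compound 4 the estimated value is 5.5 uM, with an expected range from 1.5 uM to 20 uM.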

Compound 4, concentration for half-maximal effect: 4.98 uM
The estimate for compound 4 lay 1.1-fold (0.04 log units) above the measured number, within the range that was stated.
By their numbers in this assay, from the lowest: compound 1; then compounds 3 and 4 (each within the scatter of the next). At a limit, above all of these: compound 2.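

In this assay, cyclopentyl in place of pentyl gives a 1.0-fold higher number from compound 3 to compound 4 (0.01 log units; within the scatter), so at this place, on an aromatic carbon next to the ring oxygen, the open chain and the ring cannot be told apart. Going by these compounds alone, this is the first pair differing in only one place, and it shows that closing the chain into a five-membered ring of carbon only, with the same count of carbon atoms, leaves the read-out where it was. Nothing measured here offers a reason for this match. From the compounds shown here alone, whether a longer chain such as octyl, or a cyclopentyl ring carrying an amine or a hydroxyl group, would also hold the value at this place remains open. The exchange is also tested here against only one partner and in only one cell line.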